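Methyl for methylsulfanyl on two cores: cytotoxicity notes

The compounds below may be only part of what the source reports. "The series", "measured", "known", "first", "only" and "open" are said of these compounds alone.

Compound 1 `COc1ccc2ccc(=O)oc2c1C(/C=C/c1ccc(SC)cc1)=N/NC(N)=O` and compound 2 `COc1ccc2ccc(=O)oc2c1C(/C=C/c1ccc(C)cc1)=N/NC(N)=O` share one core; compound 3 `COc1ccc2ccc(=O)oc2c1C1=NN(c2ccccc2)C(c2ccc(SC)cc2)C1` and compound 4 `COc1ccc2ccc(=O)oc2c1C1=NN(c2ccccc2)C(c2ccc(C)cc2)C1` share another. The difference between the two cores is not broken down here.

In a functional assay on HepG2 cells (Homo sapiens) for cytotoxicity, read by MTT assay, with a stated time of 72 h (on this read-out higher numbers stand for weaker inhibition and lower numbers for stronger inhibition), compound 1 gives 99 nM. Compound 2 gives 93 nM in this assay. The change from compound 1 to compound 2 is methyl in place of methylsulfanyl on an aromatic carbon, and it made a 1.1-fold lower number from compound 1 to compound 2 (0.03 log units; within the scatter). Compound 3 gives 78 nM in this assay. Set beside compound 1 and compound 2, the value of compound 3 lies within the scatter of both, so no order among the three compounds can be read from these numbers.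

Compound 4 carries the corresponding change on the second core: methyl in place of methylsulfanyl on an aromatic carbon. The place of the change reads the same for both pairs, so it is taken as the same change, occurring twice among the four compounds. For the measured compounds named here, the one measured instance of it, from compound 1 to compound 2, stayed within the scatter. On that footing the step in this assay is expected to be small as well, estimated at a 1.1-fold lower number from compound 3 to compound 4 (0.03 log units; within the scatter). This expectation rests on compound 2 giving 93 nM against compound 1, and on compound 3 giving 78 nM as the starting point. Compound 4 is therefore expected to give about 72 nM in this assay, with a likely range from 40 nM to 130 nM.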

Compound 4, half-maximal inhibitory concentration: 51 nM
Beside the measured number, compound 4's estimate is 1.4-fold (0.15 log units) above it; measured number inside the range.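

In this assay, exchanging 4-(methylsulfanyl)phenyl for 4-methylphenyl on the second core gives a 1.5-fold lower number from compound 3 to compound 4 (0.18 log units; within the scatter), so this pair, like the first, shows no change that can be told apart from the usual scatter. Set side by side, the two steps do not differ: the same change on two cores in this assay, a 1.1-fold lower number (0.03 log units; within the scatter) from compound 1 to compound 2 and a 1.5-fold lower number (0.18 log units; within the scatter) from compound 3 to compound 4, 1.4-fold (0.16 log units) apart, within the scatter of two such steps

Within these two pairs, then, the change carries from one core to the other without a detectable difference, and the small step seen on the first core is also what is seen on the second. This does not establish that the step is independent of the core, as two pairs with steps this small could hide a modest dependence on it, and it gives no rule for the rest of the series.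

As far as these compounds go, only methylsulfanyl and methyl appear at this place on the aromatic ring, so it remains open whether an amine, a carboxylic acid or a longer alkyl chain there would give a larger step, or would separate the two cores. From the compounds shown here alone, whether the exchange stays this small on a third core, or in any read-out beyond this assay, also remains open.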